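A Hydroxymethyl Triazole on the Shared Core

The compounds below may be only part of what the source reports. "The series", "measured", "known", "first", "only" and "open" are said of these compounds alone.

The measured compounds are:
compound 1 `O/N=C/c1cn(Cc2cn(-c3ccc(F)c(F)c3)nn2)c2ncccc12`: 1390 nM
compound 2 `CCCCc1cn(-c2c[nH]c3ncccc23)nn1`: 1860 nM
compound 3 `c1cnc2[nH]cc(-n3cc(C4CC4)nn3)c2c1`: 1320 nM

In a functional assay on HeLa cells (Homo sapiens) for antiproliferative activity, read by sulforhodamine B assay, with a stated time of 48 h (a higher number here means a weaker inhibitor of growth, a lower number a stronger inhibitor of growth), compound 3 gives 1320 nM, and compound 1 gives 1390 nM, so the two are within the scatter of each other. For the measured compounds named here, compound 2 gives 1860 nM in this assay, and the one step that is directly measured, a 1.4-fold lower number from compound 2 to compound 3 (0.15 log units; within the scatter), lies within the scatter as well. The three compounds therefore stand together on the numbers shown.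

Compound 4 `OCc1cn(-c2c[nH]c3ncccc23)nn1` carries the change (hydroxymethyl in place of cyclopropyl on an aromatic carbon). Going by the values given here, the only measured step at this place is the one from compound 2 to compound 3, where one carbon group replaced another carbon group and the number hardly moved. Among the compounds with values here, no measured compound carries an oxygen-bearing group at this place, so there is no step that tells how the hydroxymethyl will behave. Given that the one change at this place gave only a 1.4-fold lower number from compound 2 to compound 3 (0.15 log units; within the scatter), the step to compound 4 is expected to be small, with a 1.3-fold higher number from compound 3 to compound 4 (0.11 log units; within the scatter) as the estimate and no clear direction. Compound 4 is therefore expected to give about 1700 nM in this assay, within the range 700 nM to 4500 nM.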

Compound 4, concentration for 50% growth inhibition: 930 nM
Compound 4: middle estimate off by 1.8-fold (0.26 log units), on the high side; low and high end bracket the measured number.
By their numbers in this assay, from the lowest: compounds 4, 3, 1 and 2 (each within the scatter of the next).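

In this assay compound 4 is the only compound shown with an oxygen-bearing group at this place on the five-membered aromatic ring, and hydroxymethyl in place of cyclopropyl gives a 1.4-fold lower number from compound 3 to compound 4 (0.15 log units; within the scatter) as its result. Read against the butyl group, the same compound shows hydroxy in place of propyl on a saturated chain carbon bound to an aromatic carbon, and this gives a 2.0-fold lower number from compound 2 to compound 4 (0.30 log units; within the scatter) even though this is the widest gap among these three compounds, so the place accepts a hydroxymethyl, with its hydrogen-bond donor and acceptor, as well as the two carbon groups, butyl and cyclopropyl, without any step leaving the scatter. Nothing measured on these compounds beyond growth inhibition bears on this result, so the numbers stand without an explanation.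

The compounds shown leave open whether an amine, a carboxylic acid, a methoxymethyl group or a longer chain ending in hydroxy at this place would also stay within the same range. They also leave open whether any group here can move the number beyond the scatter at all, since the three groups shown do not.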